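The source may hold more compounds than are shown below. What is called first, only, known or untested is meant among the compounds shown, and "the series" means these compounds.

Of the compounds shown here, two built on the same core have been measured in an assay for positive allosteric modulation of metabotropic glutamate receptor 3 (Rattus norvegicus); on this read-out higher numbers stand for an effect only at larger amounts of compound and lower numbers for an effect already at smaller amounts. Compound 1 `Cc1c(OC[C@@H](C)COc2ccc(F)c(C(=O)O)c2)ccc(C(=O)CC(C)(C)C)c1O` gives 1180 nM in this assay. Compound 2 `Cc1c(OC[C@@H](C)COc2ccc(C(=O)O)c(Cl)c2)ccc(C(=O)CC(C)(C)C)c1O` gives 860 nM in this assay. Within the data shown here, the single step between them, a 1.4-fold lower number from compound 1 to compound 2 (0.14 log units; within the scatter), exchanges the groups carried by the phenyl ring that sits on an oxygen on a saturated carbon, and the two numbers lie within the scatter of each other, so compound 2 cannot be set apart from compound 1 on what has been measured.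

Compound 3 `Cc1c(OC[C@@H](C)COc2ccc3c(c2)C(=O)NC3)ccc(C(=O)CC(C)(C)C)c1O` brings a change of another kind: a group of 10 heavy atoms (8 carbon, 1 nitrogen, 1 oxygen; one five-membered non-aromatic ring with 1 hetero atom, one six-membered aromatic ring of carbon only) in place of a group of 10 heavy atoms (7 carbon, 2 oxygen, 1 chlorine; one six-membered aromatic ring of carbon only), on an oxygen on a saturated carbon. Among the measured compounds shown here, no measured step tests a change like this. For the measured compounds named here, the only step available kept a carboxylic acid on the ring and moved the number no further than the scatter, so it offers no direction for removing that acid entirely and bringing in a fused five-membered ring. The expectation is therefore uncertain and is placed close to compound 2, with a wide range around it.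

Compound 3 is expected to give roughly 1500 nM in this assay, with a range from 400 nM to 6000 nM. This expected value corresponds to an estimated step of a 1.7-fold higher number from compound 2 to compound 3 (0.24 log units; within the scatter).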

Compound 3, half-maximal effective concentration: "not active" (no number reported)
Compound 3: no number reported; there is nothing to compare the estimate with.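

In this assay, among these compounds, compound 3 is reported as not active, with no number, so no step from compound 2 to compound 3 can be read. Nothing shown here accounts for this result. The compounds shown leave open whether losing the 4-carboxy-3-chlorophenyl group or bringing in the new five-membered ring goes with this outcome.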